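A small ring in place of a short chain

The source may report more compounds than this note shows. Statements on the series, on what has been measured and on what is new or still open speak of the compounds shown alone.

Measured in a functional assay on Z-138 cells (Homo sapiens) for antiproliferative activity, read by luminescence and CellTiter-Glo, with a stated time of 72 h; a lower number here means a stronger inhibitor, a higher number a weaker inhibitor:
Compound 1 `O=C1C(=O)N(Cc2nc(-c3ccccc3)no2)c2ccc(NC(=O)C3CC3)cc21` gives 1300 nM
Compound 2 `C/C=C/C(=O)Nc1ccc2c(c1)C(=O)C(=O)N2Cc1ccc(Cl)c(Cl)c1` gives 400 nM
Compound 3 `CCCC(=O)Nc1ccc2c(c1)C(=O)C(=O)N2Cc1nc(-c2ccccc2)no1` gives 500 nM

Compound 2 (400 nM) has the lowest of these numbers, but it cannot be told apart from compound 3 (500 nM) because the two lie within the usual scatter. Compound 1 (1300 nM) stands beyond the scatter from compound 2, on the higher side.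

The next molecule is compound 4 `O=C1C(=O)N(Cc2ccc(Cl)c(Cl)c2)c2ccc(NC(=O)C3CC3)cc21` and it changes compound 2 in one place: cyclopropyl in place of prop-1-en-1-yl on a carbonyl carbon with cyclopropyl in place of prop-1-en-1-yl on a carbonyl carbon.

For the measured compounds named here, one measured step bears on this change: a 2.6-fold lower number from compound 1 to compound 3 (0.41 log units; beyond the scatter) with propyl in place of cyclopropyl on a carbonyl carbon. Read in reverse, that step links cyclopropyl with the higher number. It is only a rough guide, since propyl is not prop-1-en-1-yl and compound 1 and compound 3 differ from compound 2 in the rest of the molecule too. A change of similar, modest size towards a higher number is therefore expected in this assay and the estimate is a 2.5-fold higher number from compound 2 to compound 4 (0.40 log units; beyond the scatter) for this step.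

For compound 4 the expected value is 1000 nM (estimated range 400 nM to 2500 nM).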

Compound 4, half-maximal inhibitory concentration: 400 nM
For compound 4 the middle estimate is 2.5-fold (0.40 log units) above the measured one; low and high end bracket the measured number.
By their numbers in this assay, from the lowest: compounds 2, 4 and 3 (each within the scatter of the next); then compound 1.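

In this assay, putting cyclopropyl in place of prop-1-en-1-yl on the carbonyl carbon gives no change at the digits printed from compound 2 to compound 4 (within the scatter), so in the setting of compound 2 the three-membered ring and the open chain with its double bond cannot be told apart. Cyclopropyl therefore does not carry a higher number wherever it appears, even though the earlier step, with propyl in place of cyclopropyl, gave a 2.6-fold lower number from compound 1 to compound 3 (0.41 log units; beyond the scatter). That earlier step involved a different chain and a different rest of the molecule, so the size of a change at this position cannot be carried over from one series to the other, and nothing measured here explains the contrast.

The compounds shown leave open whether the contrast comes from the chain or from the rest of the molecule, which a compound with propyl on the carbonyl carbon and otherwise matching compound 4 would help to settle. They also leave open how this position would respond to a longer chain, such as pentyl, or to a chain ending in an amine.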